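Adding a Chloro Group to Compound 3

The compounds below may be only part of what the source reports. "The series", "measured", "known", "first", "only" and "open" are said of these compounds alone.

Cell toxicity is a routine early check on new compounds. In an ADME assay on BHK-21 cells (Mesocricetus auratus) for cytotoxicity, read by MTT assay, with a stated time of 72 h (a lower number here means that less compound is tolerated, a higher number that more compound is tolerated), compound 1 (`Cc1ccccc1C1CC(c2ccc(OCc3ccccc3)cc2)=NN1c1ccc(S(N)(=O)=O)cc1`) gives 20000 nM while compound 2 (`Cc1ccc(C2CC(c3ccccc3)=NN2c2ccc(S(N)(=O)=O)cc2)cc1`) gives 7000 nM and compound 3 (`NS(=O)(=O)c1ccc(N2N=C(c3ccc(Oc4ccccc4)cc3)CC2c2ccccc2)cc1`) gives 11000 nM in the same test. The reading for compound 3 lies within the usual scatter of repeated measurements from each of the other two readings, so it cannot be told apart from either of them.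

The compound still to be measured is compound 4 (`NS(=O)(=O)c1ccc(N2N=C(c3ccc(Oc4ccccc4)cc3)CC2c2cccc(Cl)c2)cc1`). It is compound 3 with chloro in place of hydrogen on an aromatic carbon, meta to a large group, so that phenyl becomes 3-chlorophenyl (chloro in place of hydrogen on an aromatic carbon). Going by the values given here, no two measured compounds differ in one place only, and none of them carries a chloro group, so the data hold no direct guide to this change. The best anchor is therefore compound 3 itself at 11000 nM as its measured starting point, and no step beyond the scatter is expected in this assay in either direction. The estimated move is a 1.2-fold lower number from compound 3 to compound 4 (0.06 log units; within the scatter) and it stays within the scatter. In this assay compound 4 is expected near 9500 nM with an estimated range from 4000 nM to 22000 nM around that figure.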

Compound 4, half-maximal cytotoxic concentration: 9000 nM
Beside the measured number, compound 4's estimate is 1.1-fold (0.02 log units) above it; low and high end bracket the measured number.
By their numbers in this assay, from the lowest: compounds 2, 4, 3 and 1 (each within the scatter of the next, the first and the last beyond it).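

Going by these compounds alone, compound 3 and compound 4 form the first pair here that differs in one place only, so chloro in place of hydrogen on an aromatic carbon can now be read directly: in this assay the change is a 1.2-fold lower number from compound 3 to compound 4 (0.09 log units; within the scatter). Compound 3 and compound 4 therefore cannot be told apart, and at this place, meta to a large group, turning phenyl into 3-chlorophenyl gives no difference that this test can resolve. No separate measurement accompanies this pair that could help interpret the result.

This is a single pair, so it does not show whether chloro would give the same result on another ring or on the core of compound 1 or compound 2, and one reading cannot establish a general rule for the group. It also leaves open whether a larger or differently built group at this same place, such as an amine, a carboxylic acid or a longer chain, would stay within the scatter of compound 3 or move clearly away from it.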